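A few compounds are considered here, and "the series" means these few. Any claim that something is new, unique, unknown or untested is made for them only; others in the source may bear on it.

Compound 1 `CCCCCCc1cc2c(=O)n(CCCSc3nc(-c4cc(OC)c(OC)c(OC)c4)c(C#N)c(=O)[nH]3)cnc2s1` carries a hexyl chain on its core and a three-carbon linker. In an ADME assay on A549 cells (Homo sapiens) for inhibition, read by MTT assay (on this read-out lower numbers stand for stronger inhibition of growth and higher numbers for weaker inhibition of growth), compound 1 gives 90.2 ug/mL. Compound 3 `CCCCCCCc1cc2c(=O)n(CCSc3nc(-c4cc(OC)c(OC)c(OC)c4)c(C#N)c(=O)[nH]3)cnc2s1`, which has a heptyl chain and a two-carbon linker, gives 79.7 ug/mL in this assay, and this number lies within the usual scatter of the value of compound 1, so the two cannot be told apart. Compound 2 `COc1cc(-c2[nH]c(=S)[nH]c(=O)c2C#N)cc(OC)c1OC`, the bare thione fragment without the bicyclic core, is reported only as a limit, > 100 ug/mL, which is a limit of this assay rather than a number (the limit of > 100 ug/mL in this assay, at which 1 of the 3 values shown sits).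

Compound 4 `CCCCCCCc1cc2c(=O)n(CCCSc3nc(-c4cc(OC)c(OC)c(OC)c4)c(C#N)c(=O)[nH]3)cnc2s1` is the compound still to be measured. It differs from compound 1 by methyl in place of hydrogen on a saturated chain carbon, six bonds along the chain from an aromatic carbon. Within the data shown here, no pair of measured compounds differs in exactly this way, so no measured step speaks to it directly. Compound 3 already carries the heptyl chain and sits within the scatter of compound 1, which points to a change of little weight. The expected step from compound 1 to compound 4 is a 1.1-fold lower number from compound 1 to compound 4 (0.03 log units; within the scatter), that is, none beyond the scatter. Compound 4 is therefore estimated at 85 ug/mL in this assay, with a range from 50 ug/mL to 150 ug/mL.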

Compound 4, concentration for 50% growth inhibition: 90.5 ug/mL
Compound 4: the middle estimate sits 1.1-fold (0.03 log units) below what was measured; low and high end bracket the measured number.
By their numbers in this assay, from the lowest: compounds 3, 1 and 4 (each within the scatter of the next). At a limit, above all of these: compound 2.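

Going from the hexyl chain to the heptyl chain in this assay gives a 1.0-fold higher number from compound 1 to compound 4 (0.00 log units; within the scatter), so methyl in place of hydrogen at this position, six bonds along the chain from an aromatic carbon, makes no difference that this assay can detect. Among these compounds, the earlier compounds offered no pair differing only at this place, so this is the first direct reading of the change on its own. With the rest of the molecule held the same, the chain can take this added methyl without a step beyond the scatter, but this is a single step on a single chain and does not establish a trend with chain length.

From the compounds shown here alone, compound 2 is reported only at a limit of the assay, not a number, so no step can be read from it: the limit of > 100 ug/mL in this assay, at which 1 of the 4 values shown sits. Whether a much longer chain, or an amine or a carboxylic acid at the end of the chain, would move the number beyond the scatter remains open.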